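Adding formyl to a compound stuck at a limit

A few compounds are considered here, and "the series" means these few. Any claim that something is new, unique, unknown or untested is made for them only; others in the source may bear on it.

In a functional assay on the whole organism with Mus musculus as the target (a lower number here means that less compound is needed, a higher number that more compound is needed for the effect), compound 1 (`CCN(c1ccncc1)n1cccc1`) gives > 20 mg/kg as a limit of the assay, not a number. Compound 2 (`CCCN(c1ccncc1)n1cccc1`) gives > 20 mg/kg in this assay as a limit too, so its standing is known only as a bound. The record so far is the limit of > 20 mg/kg in this assay, at which 2 of the 2 values shown sit, and no exact dose. Going by the values given here, the one measured step, a step that the two limits leave unreadable from compound 1 to compound 2 with a methyl in place of hydrogen on a saturated chain carbon, offers no size to carry over. Compound 3 (`CCCN(c1ccncc1)n1cccc1C=O`) differs from compound 2 by formyl in place of hydrogen on an aromatic carbon and places formyl in place of hydrogen on an aromatic carbon, next to the ring nitrogen. With no readable step as a guide, the expected step that the limit leaves unreadable from compound 2 to compound 3 is only a loose estimate, with no firm direction. Compound 3 is estimated at 25 mg/kg with an expected range from 10 mg/kg to 60 mg/kg in this assay once measured.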

Compound 3, dose for half-maximal effect: > 20 mg/kg
Compound 3: only a limit was reported (the forecaster's own chance of this, stated with the estimate: 65%); the middle value does not contradict the limit.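

Compound 2 and compound 3 both give a limit of the assay rather than a number, so the step between them cannot be read. The compounds shown leave open what dose any of them needs, and whether formyl changes it, because all rest on one bound: the limit of > 20 mg/kg in this assay, at which 3 of the 3 values shown sit.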